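The compounds below may be only part of what the source reports. "The series", "measured", "known", "first", "only" and "open" are said of these compounds alone.

Working notes on the series. The shared core of compound 1 `CC(C)[C@@H](CC(=O)O)NC(=O)[C@@H]1CCCN1S(=O)(=O)c1cc(Cl)cc(Cl)c1` carries an isopropyl on the saturated chain carbon bound to the amide-type nitrogen. Going by the values given here, in an assay on RPMI-8866 cells for inhibition of integrin alpha-4/beta-1 (Homo sapiens) (on this read-out lower numbers stand for stronger inhibition and higher numbers for weaker inhibition), compound 1 gives 8.9 nM, the highest of the three numbers so far. Compound 2 `O=C(O)C[C@@H](NC(=O)[C@@H]1CCN1S(=O)(=O)c1cc(Cl)cc(Cl)c1)c1ccc(OC2CC2)cc1` and compound 3 `O=C(O)C[C@@H](NC(=O)[C@@H]1CCN1S(=O)(=O)c1cc(Cl)cc(Cl)c1)c1ccc(OC(F)F)cc1` carry an aryl group at that position and each also differs from compound 1 in the core; in this assay compound 2 gives 0.31 nM and compound 3 gives 1.3 nM. Among the compounds with values here, the only single-place step so far, a 4.2-fold higher number from compound 2 to compound 3 (0.62 log units; beyond the scatter), concerns the group on the aryl oxygen, not the exchange of isopropyl for aryl, so it does not bear directly on the change in hand.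

Compound 4 `CS(=O)(=O)c1ccc([C@@H](CC(=O)O)NC(=O)[C@@H]2CCCN2S(=O)(=O)c2cc(Cl)cc(Cl)c2)cc1` is built on the core of compound 1 with the change (4-(methylsulfonyl)phenyl in place of isopropyl on a saturated chain carbon bound to an amide-type nitrogen and a saturated chain carbon). Within the data shown here, no measured step covers this exchange; what the numbers of compound 2 and compound 3 show is that both aryl-bearing compounds sit well below compound 1, and this is taken as the direction to expect. The step is expected to be a 4.5-fold lower number from compound 1 to compound 4 (0.65 log units; beyond the scatter), a lower number in this assay, though the core of compound 4 matches compound 1 and not compound 2 or compound 3, so the size is uncertain. For compound 4 a value of about 2 nM is estimated, in the range 0.5 nM to 8 nM.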

Compound 4, half-maximal inhibitory concentration: 0.55 nM
Beside the measured number, compound 4's estimate is 3.6-fold (0.56 log units) above it; measured number inside the range.
By their numbers in this assay, from the lowest: compounds 2 and 4 (each within the scatter of the next); then compound 3; then compound 1.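

In this assay, going by these compounds alone, 4-(methylsulfonyl)phenyl in place of isopropyl on a saturated chain carbon bound to an amide-type nitrogen and a saturated chain carbon gives a 16-fold lower number from compound 1 to compound 4 (1.21 log units; beyond the scatter), the first single-place reading of this exchange. Compound 2 and compound 3 also differ from compound 1 in the core, so they could not separate the change at this carbon from the change in the core; compound 4 keeps the core of compound 1 and shows that this exchange alone is enough for a large step. No independent measurement is available to explain the size of this step.

The entering group brings an aromatic ring and a methylsulfonyl group together, so this single step cannot divide its size between them, and an unsubstituted phenyl or a phenyl carrying a nitrile in place of methylsulfonyl would be needed to do so. The compounds shown also leave open whether a straight butyl chain at this carbon would stay near isopropyl, and whether the same exchange would give a step of similar size on the core of compound 2.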